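The compounds below may be only part of what the source reports. "The series", "measured", "known", "first", "only" and "open" are said of these compounds alone.

Measured compounds in a functional assay on Umbilical vein for antagonist activity at B1 bradykinin receptor (Homo sapiens), using Schild analysis, with a stated time of 30 min; a lower number here means a less potent compound, a higher number a more potent compound, by a factor of ten per unit of this negative logarithm:
compound 1 `COc1cc(C)c(S(=O)(=O)N(C)CCOCC(=O)N2CCC(C(C)(C)CN(C)C)CC2)c(C)c1` gives 7.5
compound 2 `COc1cc(C)c(S(=O)(=O)N(C)CCOCC(=O)N2CCN(C3CCN(C4CC4)CC3)CC2)c(C)c1` gives 8.5
compound 3 `COc1cc(C)c(S(=O)(=O)N(C)CCOCC(=O)N2CCN(CC3CCN(C)CC3)CC2)c(C)c1` gives 8.6

Compound 1 stands lowest of the three numbers; compound 2 sits higher and compound 3 higher still, both gaps beyond the scatter. Between compound 2 and compound 3 the step is a number 0.10 log units higher from compound 2 to compound 3 (within the scatter), so the choice of group on the ring amine nitrogen there leaves the read-out unchanged.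

Compound 4 `COc1cc(C)c(S(=O)(=O)N(C)CCOCC(=O)N2CCC(CN3CCN(C)CC3)CC2)c(C)c1` is the unmeasured member. Relative to compound 1 the change is (4-methylpiperazin-1-yl)methyl in place of 1-((dimethylamino)methyl)-1-methylethyl on a saturated ring carbon. Going by the values given here, no measured step covers this exact exchange. Among the compounds with values here, what the numbers show is that compound 1, the only compound in which the amine nitrogen of the varied group sits in no ring, is the weakest, while compound 2 and compound 3, each carrying an amine nitrogen inside a six-membered non-aromatic ring, sit higher by gaps beyond the scatter. Compound 4 moves toward that arrangement, so an upward step is expected in this assay, though with wide uncertainty, since compound 4 keeps the ring carbon attachment of compound 1 rather than the ring nitrogen attachment of compound 2 and compound 3. The expected step is a number 0.70 log units higher from compound 1 to compound 4 (beyond the scatter), and compound 4 is estimated at 8.2, within 7.5 to 8.9.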

Compound 4, negative logarithm of the antagonist equilibrium constant: 8.1
Compound 4: middle estimate off by 0.10 log units, on the high side, within the range that was stated.
By their numbers in this assay, from the lowest: compound 1; then compound 4; then compounds 2 and 3 (each within the scatter of the next).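

In this assay, the saturated ring carbon three ring bonds from the ring nitrogen now proves sensitive to its substituent: a number 0.60 log units higher from compound 1 to compound 4 (beyond the scatter) on exchanging 1-((dimethylamino)methyl)-1-methylethyl for (4-methylpiperazin-1-yl)methyl, a modest gain. Going by these compounds alone, this is the first step read at this position, as the earlier step from compound 2 to compound 3 concerned a group on a ring amine nitrogen and stayed within the scatter. The exchange adds a six-membered non-aromatic ring and a second nitrogen together, and no measurement beyond this read-out bears on the reason for the step.

Which part of the exchange carries the step stays open; a piperidin-1-ylmethyl or a morpholin-4-ylmethyl group on this ring carbon would separate the two. Also open, going by these compounds, is how a longer chain carrying the 4-methylpiperazin-1-yl group would read here.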